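The compounds below may be only part of what the source reports. "The series", "measured", "known", "first", "only" and "open" are said of these compounds alone.

Compound 1 `COc1ccc(S(=O)(=O)N2CCc3cccc(NC(=O)C(C)(C)C)c32)cc1`, compound 2 `COc1ccc(S(=O)(=O)N2CCc3cccc(NC(=O)c4cccs4)c32)cc1` and compound 3 `COc1ccc(S(=O)(=O)N2CCc3cccc(NS(=O)(=O)c4ccccc4)c32)cc1` have been measured in a functional assay on MKN-45 cells (Homo sapiens) for cytotoxicity; a higher number here means a weaker inhibitor, a lower number a stronger inhibitor: compound 1 gives 289 nM, compound 2 gives 31 nM and compound 3 gives 562 nM. Compound 2 holds the lowest of the three numbers, with a 9.3-fold lower number from compound 1 to compound 2 (0.97 log units; beyond the scatter) and an 18-fold higher number from compound 2 to compound 3 (1.26 log units; beyond the scatter) both beyond the scatter. Compound 4 `COc1ccc(S(=O)(=O)N2CCc3cccc(N)c32)cc1` differs from compound 2 in one place: hydrogen in place of (thiophen-2-yl)carbonyl on a nitrogen on an aromatic ring. Within the data shown here, no measured step removes the group on that nitrogen altogether, but the two steps that exchange it show that what sits there moves the number well beyond the scatter, and the bare amino has the least in common with the thiophene amide of compound 2. An upward step is therefore expected for compound 4, a 39-fold higher number from compound 2 to compound 4 (1.59 log units; beyond the scatter). Compound 4 is estimated at 1200 nM, in the range 250 nM to 6000 nM.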

Compound 4, half-maximal inhibitory concentration: 1200 nM
Compound 4: the middle estimate sits on the measured number at the digits printed; low and high end bracket the measured number.
By their numbers in this assay, from the lowest: compound 2; then compounds 1 and 3 (each within the scatter of the next); then compound 4.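

In this assay hydrogen on this nitrogen gives a higher number than each of the three groups it replaces: (thiophen-2-yl)carbonyl (a 39-fold higher number from compound 2 to compound 4 (1.59 log units; beyond the scatter)), (tert-butyl)carbonyl (a 4.2-fold higher number from compound 1 to compound 4 (0.62 log units; beyond the scatter)) and phenylsulfonyl (a 2.1-fold higher number from compound 3 to compound 4 (0.33 log units; beyond the scatter)). All three groups thus go with a lower number than the bare amino, and the step is largest for the (thiophen-2-yl)carbonyl group. Nothing available here accounts for these differences in step size. The compounds shown leave open whether a furan-2-ylcarbonyl or benzoyl group on this nitrogen would match the thiophene amide.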